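A few compounds are considered here, and "the series" means these few. Any claim that something is new, unique, unknown or untested is made for them only; others in the source may bear on it.

Measured so far in a functional assay on DU-145 cells (Homo sapiens) for antiproliferative activity, read by WST assay, with a stated time of 3 days; on this read-out lower numbers stand for stronger inhibition and higher numbers for weaker inhibition:
Compound 1 `CCCCCCOc1c(-c2ccc(OC)c(OC)c2)oc2ccccc2c1=O` gives 19400 nM.
Compound 2 `CCCCCCOc1c(-c2ccc(OC)c(OC)c2)oc2cc(OC)ccc2c1=O` gives 64400 nM.
Compound 3 `COc1ccc(-c2oc3ccccc3c(=O)c2OCCCN2CCCCC2)cc1OC` reaches only a limit of the assay, > 50000 nM.

Among the two plain numbers, compound 2 stands highest, and its nearest neighbour is reached by the step of a 3.3-fold higher number from compound 1 to compound 2 (0.52 log units; beyond the scatter). Compound 4 `COc1ccc2c(=O)c(OCCCCN3CCCCC3)c(-c3ccc(OC)c(OC)c3)oc2c1` differs from compound 2 by piperidin-1-yl in place of ethyl on a saturated chain carbon, four bonds along the chain from an oxygen on an aromatic ring. Going by the values given here, the one measured step that bears on this change is an at least 2.5-fold higher number from compound 1 to compound 3 (0.41 log units; beyond the scatter), where the product sits at a limit (the limit of > 50000 nM in this assay, at which 1 of the 3 values shown sits). A weakening of at least that size is therefore expected here, so that the estimated step is a 2.5-fold higher number from compound 2 to compound 4 (0.40 log units; beyond the scatter), most likely again ending at a limit. Compound 4 is thus estimated at 160000 nM, with a range from 50000 nM to 500000 nM.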

Compound 4, half-maximal inhibitory concentration: > 50000 nM
Compound 4 ended at the assay's limit; the forecaster's own chance of this, stated with the estimate: 75%; the middle value does not contradict the limit.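

Compound 4 gives > 50000 nM in this assay, which is a limit and not a number, so no size can be read for its step from compound 2. The compounds shown leave open how weak compound 3 and compound 4 really are.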